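Acetylated thioglycoside series: removing decyl from the amide chain

The compounds below may be only part of what the source reports. "The series", "measured", "known", "first", "only" and "open" are said of these compounds alone.

compound 1 `CCCCCCCCCCCCCCCCCC(=O)Nc1nnc(S[C@@H]2O[C@H](COC(C)=O)[C@H](OC(C)=O)[C@H](OC(C)=O)[C@H]2OC(C)=O)s1` gives 97500 nM
compound 2 `CCCCCCCC(=O)Nc1nnc(S[C@@H]2O[C@H](CO)[C@H](O)[C@H](O)[C@H]2O)s1` gives 50800 nM
compound 3 `CCCCCCCCCCCCCC(=O)Nc1nnc(S[C@@H]2O[C@H](CO)[C@H](O)[C@H](O)[C@H]2O)s1` gives 31000 nM

In a functional assay on HeLa cells (Homo sapiens) for cytotoxicity, read by MTT assay, with a stated time of 24 h (on this read-out higher numbers stand for weaker inhibition and lower numbers for stronger inhibition), compound 1 holds the highest of the three numbers; compound 2 sits within the scatter of it, while compound 3 lies beyond it. Compound 4 `CCCCCCCC(=O)Nc1nnc(S[C@@H]2O[C@H](COC(C)=O)[C@H](OC(C)=O)[C@H](OC(C)=O)[C@H]2OC(C)=O)s1` is compound 1 with hydrogen in place of decyl on a saturated chain carbon, seven bonds along the chain from a carbonyl carbon. Among the compounds with values here, the one measured step at the same place is a 1.6-fold lower number from compound 2 to compound 3 (0.21 log units; within the scatter), which ran the other way, adding hexyl rather than removing decyl, and stayed within the scatter. Taking away decyl is the larger change, so a modest drift toward a higher number is expected, yet nothing clearly beyond the scatter. Compound 4 is estimated at 120000 nM, with a range of 50000 nM to 300000 nM, an expected step of a 1.2-fold higher number from compound 1 to compound 4 (0.09 log units; within the scatter).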

Compound 4, half-maximal inhibitory concentration: 43600 nM
Compound 4: middle estimate off by 2.8-fold (0.44 log units), on the high side, outside the stated range (below it).
By their numbers in this assay, from the lowest: compounds 3, 4, 2 and 1 (each within the scatter of the next, the first and the last beyond it).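

In this assay, hydrogen in place of decyl in the acetylated series gives a 2.2-fold lower number from compound 1 to compound 4 (0.35 log units; beyond the scatter), so chain length at this carbon can move the number beyond the scatter. Within the data shown here, the only earlier step at this place, a 1.6-fold lower number from compound 2 to compound 3 (0.21 log units; within the scatter), stayed within the scatter and could not show this. No available evidence accounts for the step. Still open, on these data alone, is whether an amine or a carboxylic acid at this chain carbon would give a step of similar size. Also open, as far as these compounds go, is whether a chain of intermediate length would fall between compound 1 and compound 4.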